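This account rests on a few compounds, and the source may have more. Where it says the series, first, only, none or still open, it means among the compounds named here.

For the measured compounds named here, compound 2, `O=C1CC[C@@H](C(=O)N2CCC(NS(=O)(=O)c3cc(S(=O)(=O)c4ccccc4)ccc3C(F)(F)F)CC2)N1`, gives 90 nM in an assay on isolated protein for binding affinity to secreted frizzled-related protein 1 (Homo sapiens), read by fluorescence (on this read-out higher numbers stand for weaker inhibition and lower numbers for stronger inhibition), the lowest of the two numbers measured so far. Going by the values given here, its only neighbour is compound 1, `CN(C)CC(=O)N1CCC(NS(=O)(=O)c2cc(S(=O)(=O)c3ccccc3)ccc2C(F)(F)F)CC1`, which gives 300 nM in this assay. Among the compounds with values here, the single measured step, a 3.3-fold lower number from compound 1 to compound 2 (0.52 log units; beyond the scatter), came from exchanging the group on the carbonyl carbon attached to the ring nitrogen, and it is the only step that bears on what follows.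

Compound 3, `CC(C)C(=O)N1CCC[C@H]1C(=O)N1CCC(NS(=O)(=O)c2cc(S(=O)(=O)c3ccccc3)ccc2C(F)(F)F)CC1`, differs from compound 2 in the same position: 1-(isopropylcarbonyl)pyrrolidin-2-yl in place of 5-oxopyrrolidin-2-yl on a carbonyl carbon. Within the data shown here, the one measured step does not repeat this change; it exchanged an acyclic amine for a lactam, whereas here the lactam gives way to a larger pyrrolidine acylated with an isopropylcarbonyl group, and the hydrogen-bond donor counted in the leaving group is lost. Compound 1, which also lacks that donor, sits at the higher number, so a return toward it cannot be ruled out, yet the shared ring may hold part of the gain.

Compound 3 is therefore expected to show a small step toward a higher number, a 1.8-fold higher number from compound 2 to compound 3 (0.25 log units; within the scatter), not far beyond the scatter. The estimate for compound 3 in this assay is 160 nM, with a range from 50 nM to 500 nM.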

Compound 3, half-maximal inhibitory concentration: 40 nM
Beside the measured number, compound 3's estimate is 4.0-fold (0.60 log units) above it, outside the stated range (below it).
By their numbers in this assay, from the lowest: compound 3; then compound 2; then compound 1.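

In this assay, putting 1-(isopropylcarbonyl)pyrrolidin-2-yl in place of 5-oxopyrrolidin-2-yl on the carbonyl carbon gives a 2.3-fold lower number from compound 2 to compound 3 (0.35 log units; beyond the scatter), so the number at this position keeps falling even though the entering group, with its 10 heavy atoms against 6, is larger and counts 0 hydrogen-bond donors against 1. The hydrogen-bond donor of 5-oxopyrrolidin-2-yl is therefore not required for a low number here, and the larger group is accommodated without any loss in this assay. Measured against (dimethylamino)methyl, the same group gives a 7.5-fold lower number from compound 1 to compound 3 (0.88 log units; beyond the scatter), which places compound 3 lowest of the three, with both its steps beyond the scatter, although nothing available explains why the number falls.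

The two changes in the ring, the loss of the lactam carbonyl and the addition of the isopropylcarbonyl group on the ring nitrogen, arrive together in compound 3, so their separate shares stay unresolved. As far as these compounds go, it remains open how an unsubstituted pyrrolidin-2-yl, or an acetyl or a benzoyl group in place of the isopropylcarbonyl on that ring nitrogen, would read in this assay.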